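A few compounds are considered here, and "the series" means these few. Any claim that something is new, unique, unknown or untested is made for them only; others in the source may bear on it.

Measured so far in a functional assay on HCT-15 cells (Homo sapiens) for cytotoxicity, read by sulforhodamine B assay, with a stated time of 48 h; on this read-out lower numbers stand for higher toxicity in this test and higher numbers for lower toxicity in this test:
compound 1 `ClCc1ccc(Cn2cnc3c(Cl)ncnc32)cc1`, 63100 nM
compound 2 `ClCc1cccc(Cn2cnc3c(Cl)ncnc32)c1`, 10000 nM
compound 3 `ClCc1ccccc1Cn1cnc2ncnc(Cl)c21`, 6160 nM

Compound 3 gives the lowest number of the three in this assay. Compound 2 sits within the usual scatter of it, so these two cannot be ordered; compound 1 lies beyond the scatter and carries the highest number of the set. Compound 4 `ClCc1ccccc1Cn1cnc2nc(Cl)nc(Cl)c21` has not been measured in this assay. It differs from compound 3 in one place: chloro in place of hydrogen on an aromatic carbon, between two ring nitrogen atoms of the shared core. Within the data shown here, no step of this kind between measured compounds is available, so its size is open. A small shift is expected, probably within the scatter, if anything toward a lower number. For compound 4 the estimate is 4000 nM, with a range of 1000 nM to 15000 nM. The step this implies is expected to be a 1.5-fold lower number from compound 3 to compound 4 (0.19 log units; within the scatter).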

Compound 4, concentration lethal to 50% of the cells: 950 nM
Estimate against measurement, compound 4: 4.2-fold (0.62 log units) above, outside the stated range (below it).
By their numbers in this assay, from the lowest: compound 4; then compounds 3 and 2 (each within the scatter of the next); then compound 1.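

In this assay chloro in place of hydrogen on an aromatic carbon, between two ring nitrogen atoms of the shared core, gives a 6.5-fold lower number from compound 3 to compound 4 (0.81 log units; beyond the scatter) and so lies beyond the scatter. Among these compounds, this carbon of the core is therefore a site where one added chlorine changes the read-out, which the earlier compounds, with no one-place step among them, could not show. No measurement at hand accounts for the shift.

From the compounds shown here alone, whether the shift is particular to chloro stays open, since an amine or a methoxy group at this carbon would test that. Going by these compounds, whether the same change carries over to compound 1 and compound 2 also stays open.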